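Shortening an Alkenyl Ether Chain on a Weak Inhibitor

This account rests on a few compounds, and the source may have more. Where it says the series, first, only, none or still open, it means among the compounds named here.

Measured so far:
compound 1 `C=CCCCCOc1ccccc1-c1cnc(OCCC=C)n1C`: 33000 nM
compound 2 `C=CCCCCOc1ccccc1-c1cnc(OCCCCC=C)n1C`: 7000 nM
compound 3 `C=CCCCCOc1ccccc1-c1cnc(S(=O)(=O)c2ccccc2)n1C`: 63000 nM

All three were tested in a functional assay on U-373MG ATCC cells (Homo sapiens) for inhibition, read by colorimetric assay and MTT assay, with a stated time of 72 h; a higher number here means a weaker inhibitor, a lower number a stronger inhibitor. Compound 3 differs from compound 2 in its core by phenylsulfonyl in place of (hex-5-en-1-yl)oxy on an aromatic carbon, and the step is a 9.0-fold higher number from compound 2 to compound 3 (0.95 log units; beyond the scatter). Compound 1 differs from compound 2 by vinyl in place of but-3-en-1-yl on a saturated chain carbon, two bonds along the chain from an oxygen on an aromatic ring, and this change gave a 4.7-fold higher number from compound 2 to compound 1 (0.67 log units; beyond the scatter). Compound 4 `C=CCCOc1ccccc1-c1cnc(S(=O)(=O)c2ccccc2)n1C` is not yet measured; it differs from compound 3 by vinyl in place of but-3-en-1-yl on a saturated chain carbon, two bonds along the chain from an oxygen on an aromatic ring, the same change at the same place. Because the earlier step was a 4.7-fold higher number from compound 2 to compound 1 (0.67 log units; beyond the scatter), a step of similar size, a 4.0-fold higher number from compound 3 to compound 4 (0.60 log units; beyond the scatter), is expected for compound 4, though this rests on a single prior pair. Compound 4 is therefore estimated at 250000 nM, with a range from 80000 nM to 700000 nM.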

Compound 4, half-maximal inhibitory concentration: > 100000 nM
Compound 4: no number, only a limit; the forecaster's own chance of this, stated with the estimate: 40%; the middle value lies beyond the limit too.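

In this assay compound 4 gives > 100000 nM, which is a limit of the assay and not a number. Cutting hex-5-en-1-yl to but-3-en-1-yl on the core carrying phenylsulfonyl gives an at least 1.5-fold higher number from compound 3 to compound 4 (0.20 log units; that floor lies within the scatter), and this is a floor, not a measured size. A step of similar size on both cores is therefore allowed but not shown: the same change on two cores in this assay, a 4.7-fold higher number (0.67 log units; beyond the scatter) from compound 2 to compound 1 and an at least 1.5-fold higher number (0.20 log units; that floor lies within the scatter) from compound 3 to compound 4; the limit leaves it open whether they differ

The compounds shown leave open what a longer chain than hex-5-en-1-yl would do to the number on either core. They also leave open whether an amine or a carboxylic acid at the end of the chain, in place of the double bond, would give a stronger inhibitor.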